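Aryl ketone exchange on the shared core: cytotoxicity notes

This account rests on a few compounds, and the source may have more. Where it says the series, first, only, none or still open, it means among the compounds named here.

Measured so far:
Compound 1, `COc1cccc(C(=O)c2sc3nc(-c4cccs4)ccc3c2N)c1`: 0.03 ug/mL
Compound 2, `Nc1c(C(=O)c2cccc(F)c2)sc2nc(-c3cccs3)ccc12`: 0.025 ug/mL

Both numbers come from a functional assay on WI-38 VA13 cells (Homo sapiens) for cytotoxicity; on this read-out higher numbers stand for an effect only at larger amounts of compound and lower numbers for an effect already at smaller amounts. Compound 2 and compound 1 lie within the scatter of each other: the step of a 1.2-fold lower number from compound 1 to compound 2 (0.08 log units; within the scatter) does not separate them, so compound 2 stands level with compound 1 on the numbers at hand rather than apart from it.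

Compound 3, `Nc1c(C(=O)c2ccc(Br)cc2)sc2nc(-c3cccs3)ccc12`, has not yet been measured in this assay. It differs from compound 2 by 4-bromophenyl in place of 3-fluorophenyl on a carbonyl carbon. Going by the values given here, the only measured step, a 1.2-fold lower number from compound 1 to compound 2 (0.08 log units; within the scatter), also exchanged one substituent for another on the aryl ring of the ketone and stayed within the scatter; that is the sole point of reference. Among the compounds with values here, no measured compound carries a substituent placed as in 4-bromophenyl, and no measured compound carries bromine, so the step to compound 3 is not covered directly. The expectation is therefore a step of about a 1.2-fold higher number from compound 2 to compound 3 (0.08 log units; within the scatter), that is, nothing beyond the scatter. Compound 3 is expected at 0.03 ug/mL in this assay, with a range from 0.01 ug/mL to 0.1 ug/mL.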

Compound 3, half-maximal effective concentration: 2.8 ug/mL
Estimate against measurement, compound 3: 93-fold (1.97 log units) below; the whole stated range lies below it.
By their numbers in this assay, from the lowest: compounds 2 and 1 (each within the scatter of the next); then compound 3.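

In this assay, the aryl group on the carbonyl carbon proves far from indifferent to exchange: a 110-fold higher number from compound 2 to compound 3 (2.05 log units; beyond the scatter) with 4-bromophenyl in place of 3-fluorophenyl, and a 93-fold higher number from compound 1 to compound 3 (1.97 log units; beyond the scatter) with 4-bromophenyl in place of 3-methoxyphenyl. The earlier exchange between 3-methoxyphenyl and 3-fluorophenyl had stayed within the scatter, so the series now shows that this position can hold one aryl exchange without a separation in the numbers and yet give a large step with another, even though 3-fluorophenyl and 4-bromophenyl match in heavy-atom count, hydrogen-bond donors, hydrogen-bond acceptors and net charge. No measurement at hand accounts for the size of this step.

The compounds shown do not tell whether the bromine or the placement of the substituent in 4-bromophenyl carries the step, since both differ from compound 1 and compound 2 at once. Also open, from the compounds shown here alone, is whether an aryl ketone bearing an amine or a carboxylic acid would stand level with compound 1 and compound 2 or move towards compound 3.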